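From a Limit to an Ethoxy Group

The compounds below may be only part of what the source reports. "The series", "measured", "known", "first", "only" and "open" are said of these compounds alone.

Measured in a functional assay on HL-60 cells (Homo sapiens) for antiproliferative activity, read by MTT assay, with a stated time of 72 h; a lower number here means a stronger inhibitor, a higher number a weaker inhibitor:
- compound 1 `COc1cc(C(=O)c2sc3ccccc3c2-c2ccc(Cl)cc2)cc(OC)c1OC`: 3300 nM
- compound 2 `COc1ccc(-c2c(C(=O)c3cc(OC)c(OC)c(OC)c3)sc3ccccc23)cc1`: 1600 nM
- compound 3 `COc1ccc(-c2c(C(=O)c3cc(OC)c(OC)c(OC)c3)sc3ccccc23)cc1C`: > 10000 nM (a limit, not a number)

Compound 3 gives no number in this assay, only a limit: the limit of > 10000 nM in this assay, at which 1 of the 3 values shown sits. The next structure, compound 4 `CCOc1ccc(-c2c(C(=O)c3cc(OC)c(OC)c(OC)c3)sc3ccccc23)cc1`, has 4-ethoxyphenyl in place of 4-methoxy-3-methylphenyl on an aromatic carbon, with the same atoms joined differently: 4-ethoxyphenyl in place of 4-methoxy-3-methylphenyl on an aromatic carbon.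

Among the compounds with values here, three measured steps bear on this change. Methyl in place of hydrogen on an aromatic carbon gave an at least 6.2-fold higher number from compound 2 to compound 3 (0.79 log units; beyond the scatter), the largest of the three. Methoxy in place of chloro gave a 2.1-fold lower number from compound 1 to compound 2 (0.31 log units; beyond the scatter), a modest step. The group of compound 3 in place of 4-chlorophenyl gave an at least 3.0-fold higher number from compound 1 to compound 3 (0.48 log units; beyond the scatter). Within the data shown here, no measured compound carries the ethoxy group, but compound 4 lacks the methyl that marks the step to compound 3, so a clear move to a lower number is expected. The expected step is an at least 3.3-fold lower number from compound 3 to compound 4 (0.52 log units; beyond the scatter). The estimate for compound 4 is 3000 nM, with an expected range from 1000 nM to 9000 nM.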

Compound 4, half-maximal inhibitory concentration: 3500 nM
Estimate against measurement, compound 4: 1.2-fold (0.07 log units) below; the range from low to high includes it.
By their numbers in this assay, from the lowest: compound 2; then compounds 1 and 4 (each within the scatter of the next). At a limit, above all of these: compound 3.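

In this assay, rearranging the same atoms from 4-methoxy-3-methylphenyl to 4-ethoxyphenyl gave an at least 2.8-fold lower number from compound 3 to compound 4 (0.45 log units; beyond the scatter), so at this place on the five-membered ring the arrangement of these atoms matters, and an added carbon on the saturated chain is compatible with a measurable value. That added carbon is still not neutral, as extending methoxy to ethoxy gave a 2.2-fold higher number from compound 2 to compound 4 (0.34 log units; beyond the scatter), while ethoxy in place of chloro gave a 1.1-fold higher number from compound 1 to compound 4 (0.03 log units; within the scatter). Compound 3 carries only a limit, so the step from it is a bound and not a size: the limit of > 10000 nM in this assay, at which 1 of the 4 values shown sits.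

The compounds shown leave open whether a longer chain such as propoxy would continue the rise seen from methoxy to ethoxy. They also leave open what an amine such as dimethylamino would give at the same place on the phenyl ring.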